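Alpha-ketoamide calpain inhibitors: amide substituent variation

The compounds below may be only part of what the source reports. "The series", "measured", "known", "first", "only" and "open" are said of these compounds alone.

Measured so far:
compound 1, `CCOC(=O)C(=O)[C@H](CC)NC(=O)[C@H](CC(C)C)NC(=O)[C@H](CC(C)C)NC(=O)c1ccc2ccccc2c1`: 90 nM
compound 2, `CCC(NC(=O)C(CC(C)C)NC(=O)OCc1ccccc1)C(=O)C(=O)NCC(C)C`: 140 nM

In an assay on isolated protein (Oryctolagus cuniculus) for inhibition of Calpain-2 catalytic subunit (Homo sapiens), at pH 8.0 (a lower number here means a stronger inhibitor, a higher number a weaker inhibitor), compound 1 gives 90 nM and compound 2 gives 140 nM; the two numbers lie within the scatter of each other, so neither compound can be called the stronger. Compound 3, `CCC(NC(=O)C(CC(C)C)NC(=O)OCc1ccccc1)C(=O)C(=O)NCCCc1ccccc1`, carries phenethyl in place of isopropyl on a saturated chain carbon bound to an amide-type nitrogen. Among the compounds with values here, no measured pair shows this change, so the expectation rests on analogy only. For compound 3 a small step toward a lower number in this assay is expected, a 1.8-fold lower number from compound 2 to compound 3 (0.24 log units; within the scatter), not clearly beyond the scatter. Compound 3 is therefore estimated at 80 nM, with a range of 25 nM to 300 nM.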

Compound 3, inhibition constant: 43 nM
Compound 3: middle estimate off by 1.9-fold (0.27 log units), on the high side, and the stated range covers the measured number.
By their numbers in this assay, from the lowest: compound 3; then compounds 1 and 2 (each within the scatter of the next).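

In this assay, phenethyl in place of isopropyl on a saturated chain carbon bound to an amide-type nitrogen gives a 3.3-fold lower number from compound 2 to compound 3 (0.51 log units; beyond the scatter), a modest step beyond the scatter. This place therefore accepts the larger group with its six-membered aromatic ring, and the number moves in the stronger direction. No available data explain the step.

Going by these compounds, whether the aromatic ring or the longer chain carries the step stays open. A straight hexyl chain, a benzyl group, or an amine or carboxylic acid on the aromatic ring would separate these readings.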